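Ethoxycarbonyl in place of 1,3-benzothiazol-2-yl: working notes

The source may report more compounds than this note shows. Statements on the series, on what has been measured and on what is new or still open speak of the compounds shown alone.

Measured in a toxicity assay on NIH3T3 cells (Mus musculus) for cytotoxicity, read by resazurin assay; a lower number here means that less compound is needed, a higher number that more compound is needed for the effect:
- Compound 1 `CC(=O)c1ccc(NCc2cncn2Cc2ccc(-c3ccccc3)cc2)cc1-c1ccccc1`: > 10000 nM
- Compound 2 `c1ccc(-c2ccc(Cn3cncc3CNc3cccc(-c4ccccc4)c3)cc2)cc1`: 10000 nM
- Compound 3 `c1ccc(-c2ccc(Cn3cncc3CNc3ccc(-c4nc5ccccc5s4)c(-c4ccccc4)c3)cc2)cc1`: > 1000 nM

Compound 3 stands at the limit of > 1000 nM in this assay, at which 1 of the 3 values shown sits, which is a limit and not a number. Compound 1 stands at the limit of > 10000 nM in this assay, at which 1 of the 3 values shown sits, also a limit. Only compound 2 gives a number.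

The next structure is compound 4 `CCOC(=O)c1ccc(NCc2cncn2Cc2ccc(-c3ccccc3)cc2)cc1-c1ccccc1`, with ethoxycarbonyl in place of 1,3-benzothiazol-2-yl on an aromatic carbon.

Three measured steps change the same group: a number no higher from compound 1 to compound 2 (the limit leaves the size open), a step that the two limits leave unreadable from compound 1 to compound 3 and a step that the limit leaves unreadable from compound 2 to compound 3. None of them has a readable size, so they set no firm size for the new step. The closest guide is compound 1, which carries acetyl and reads > 10000 nM, a limit. Compound 2 adds the number 10000 nM. In this assay a move toward a higher number is therefore expected, though its size remains loose. The expected step is a step that the limit leaves unreadable from compound 3 to compound 4. For compound 4 the estimate is 10000 nM, with an expected range of 4000 nM to 30000 nM.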

Compound 4, half-maximal effective concentration: > 10000 nM
Compound 4 gave a limit, no number (the forecaster's own chance of this, stated with the estimate: 60%); the middle value sits exactly at the limit.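

In this assay compound 4 gives > 10000 nM, which is a limit of the assay and not a number. Against the unsubstituted compound, ethoxycarbonyl at this position, ortho to a phenyl group and para to a large group, gives a number no lower from compound 2 to compound 4 (the limit leaves the size open), so a second carbonyl-containing group after the acetyl of compound 1 now reads as a limit here. The steps from compound 3 and from compound 1 to compound 4 cannot be read, and the exchange of methyl for ethoxy on the carbonyl carbon therefore has no size.

Going by these compounds, how far compound 1 and compound 4 lie past their shared limit stays open. Also open, on these data alone, is what a carboxylic acid or an amine at this position would read in this assay, and whether either would fall under compound 2 at 10000 nM.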